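A few compounds are considered here, and "the series" means these few. Any claim that something is new, unique, unknown or untested is made for them only; others in the source may bear on it.

Measured so far in a functional assay on A549 cells (Homo sapiens) for antiproliferative activity, read by sulforhodamine B assay, with a stated time of 72 h; on this read-out lower numbers stand for stronger inhibition and higher numbers for weaker inhibition:
- Compound 1 `O=C(/C=C/c1csc2ccccc12)c1cccc(Cl)c1` gives > 10000 nM, a limit.
- Compound 2 `O=C(/C=C/c1cc2ccccc2s1)c1cc(Cl)ccc1O` gives > 10000 nM, a limit.
- Compound 3 `O=C(/C=C/c1cc2ccccc2s1)c1cc(Br)ccc1O` gives > 10000 nM, a limit.

None of these entries is a true number, so compound 2 cannot be ranked against the others. The shared result is the limit of > 10000 nM in this assay, at which 3 of the 3 values shown sit. Within the data shown here, all that can be said is that no compound here has reached a measurable inhibition of cell growth in this assay.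

The next compound is compound 4 `O=C(/C=C/c1cc2ccccc2s1)c1cc(Cl)cc(Cl)c1O`, which keeps the whole of compound 2 and changes one place: chloro in place of hydrogen on an aromatic carbon. The new chloro stands ortho to a hydroxy group and meta to the chloro group already present.

Among the measured compounds shown here, only one measured step comes close to this change, a swap of bromo in place of chloro on an aromatic carbon: a step that the two limits leave unreadable from compound 2 to compound 3. That step gives no size to carry over, and it involves a swap rather than an added group. Compound 3 still reports > 10000 nM, which is a limit. A further limit is therefore the most likely outcome, with no readable change in either direction. The expected size is a number no higher from compound 2 to compound 4 (the limit leaves the size open). For compound 4 the estimate is 10000 nM, with an expected range from 3000 nM to 30000 nM.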

Compound 4, half-maximal inhibitory concentration: 6900 nM
Estimate against measurement, compound 4: 1.4-fold (0.16 log units) above; the measured number falls inside the stated range.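

In this assay, among these compounds, compound 4 is the first compound in this set to give a true number rather than a limit, while the other compounds stay at that limit: the limit of > 10000 nM in this assay, at which 3 of the 4 values shown sit.

The added chloro sits on an aromatic carbon, ortho to a hydroxy group and meta to a chloro group, and it gives an at least 1.4-fold lower number from compound 2 to compound 4 (0.16 log units; that floor lies within the scatter) as the only size that can be read for this change. Compound 2 carries only a limit, so this size is a floor: the true difference may be larger, but the part that can be read does not by itself go beyond ordinary scatter.

Going by these compounds, it remains open whether this result needs a chloro in particular, or whether a fluoro, a methyl or an amine on the same carbon would give a similar number. On these data alone, it is also open how the result would shift if a methoxy group or an amine took the place of the hydroxy group.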